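The source may report more compounds than this note shows. Statements on the series, on what has been measured and on what is new or still open speak of the compounds shown alone.

Measured so far:
Compound 1, `O=C(CSc1nc2c(c(=O)n1-c1ccccc1)SCC2)Nc1nc2ccc(Cl)cc2s1`: 40 nM
Compound 2, `O=C(CNC(=O)c1nn(-c2ccccc2)c(=O)c2ccccc12)Nc1nc2ccc(Cl)cc2s1`: 30 nM
Compound 3, `O=C(CSc1nc2c(c(=O)n1-c1ccccc1)SCC2)Nc1nc2ccc(C(F)(F)F)cc2s1`: 40 nM

These values come from an assay on L cells for inhibition of Protein-serine O-palmitoleoyltransferase porcupine (Mus musculus), read by reporter gene assay, with a stated time of 24 h; a lower number here means that less compound is needed, a higher number that more compound is needed for the effect. Compound 1 and compound 2 carry different cores; the difference between the two cores is not broken down here. Their values in this assay lie within the scatter of each other, as do those of compound 3.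

Compound 3 is compound 1 with one change, (trifluoromethyl in place of chloro on an aromatic carbon). That step, no change at the digits printed from compound 1 to compound 3 (within the scatter), shows no effect that can be told from repeat scatter.

Compound 4, `O=C(CNC(=O)c1nn(-c2ccccc2)c(=O)c2ccccc12)Nc1nc2ccc(C(F)(F)F)cc2s1`, has not yet been measured. It stands to compound 2 as compound 3 stands to compound 1: the change is trifluoromethyl in place of chloro on an aromatic carbon, at a place described in the same words in both pairs, so it is the same change on a different core.

The expectation for compound 4 rests on compound 2 and its value 30 nM together with the earlier step of no change at the digits printed from compound 1 to compound 3 (within the scatter), which suggests the change leaves the number about where it was. The step from compound 2 to compound 4 in this assay is therefore expected to be no change at the digits printed from compound 2 to compound 4 (within the scatter). Compound 4 is accordingly estimated at 30 nM, with a likely range from 12 nM to 75 nM.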

Compound 4, half-maximal effective concentration: 110 nM
Estimate against measurement, compound 4: 3.7-fold (0.56 log units) below; measured number outside the range, above it.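

In this assay, trifluoromethyl in place of chloro on an aromatic carbon now gives a 3.7-fold higher number from compound 2 to compound 4 (0.56 log units; beyond the scatter), meaning that more compound is needed for the effect. Set beside the earlier step, the same change does not carry over unaltered from one core to the other: the same change on two cores in this assay, no change at the digits printed (within the scatter) from compound 1 to compound 3 and a 3.7-fold higher number (0.56 log units; beyond the scatter) from compound 2 to compound 4, 3.7-fold (0.56 log units) apart, beyond the scatter of two such steps. This shows that, for these two pairs, a step measured on one core could not be transferred to the other, but it does not show which part of the cores is responsible or how the change would behave on any further core.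

The compounds shown leave open whether other groups on that aromatic carbon, such as a methyl, a methoxy or a nitrile, would also give different steps on the two cores. They also leave open whether a smaller halogen such as fluoro would stay closer to chloro on both cores.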